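Thioether aryl variation on the shared core: nitro for dichloro

The source may hold more compounds than are shown below. What is called first, only, known or untested is meant among the compounds shown, and "the series" means these compounds.

Three thioethers on the shared core have been measured. Compound 1 `Cc1cc(C)c(SCc2ncnc3c2ncn3[C@@H]2O[C@H](CO)[C@@H](O)[C@H]2O)c(C)c1` gives 33100 nM in an assay on isolated protein for binding affinity to Equilibrative nucleoside transporter 1 (Homo sapiens); a higher number here means a weaker inhibitor, a lower number a stronger inhibitor. Compound 2 `OC[C@H]1O[C@@H](n2cnc3c(CSc4ccccc4Cl)ncnc32)[C@H](O)[C@@H]1O` gives 1780 nM in this assay, and compound 3 `OC[C@H]1O[C@@H](n2cnc3c(CSc4ccc(Cl)c(Cl)c4)ncnc32)[C@H](O)[C@@H]1O` gives 224 nM. The step of a 19-fold lower number from compound 1 to compound 2 (1.27 log units; beyond the scatter) and the step of a 150-fold lower number from compound 1 to compound 3 (2.17 log units; beyond the scatter) are both large; the step of a 7.9-fold lower number from compound 2 to compound 3 (0.90 log units; beyond the scatter) is modest. Compound 3 therefore holds the lowest number of the three, with compound 2 the nearest and compound 1 the furthest.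

Compound 4 `O=[N+]([O-])c1cccc(SCc2ncnc3c2ncn3[C@@H]2O[C@H](CO)[C@@H](O)[C@H]2O)c1` differs from compound 3 in one place: 3-nitrophenyl in place of 3,4-dichlorophenyl on a sulfur. For the measured compounds named here, no measured step exchanges a chlorine-bearing phenyl for a nitro-bearing one, so the closest bearings are the steps on the same sulfur, a 7.9-fold lower number from compound 2 to compound 3 (0.90 log units; beyond the scatter) and a 150-fold lower number from compound 1 to compound 3 (2.17 log units; beyond the scatter), which show that the aryl substituent alone moves this read-out by modest to large amounts. From the compounds shown here alone, all measured aryl groups in this set carry only carbon-bound substituents; a group with two hydrogen-bond acceptors is untested here. With compound 3 as the anchor, a modest step upward is expected, a 3.1-fold higher number from compound 3 to compound 4 (0.49 log units; beyond the scatter), though a step in either direction is plausible. Compound 4 is estimated at 700 nM, with a range from 150 nM to 3500 nM.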

Compound 4, half-maximal inhibitory concentration: 4.79 nM
Compound 4: the middle estimate sits 150-fold (2.16 log units) above what was measured, outside the stated range (below it).
By their numbers in this assay, from the lowest: compound 4; then compound 3; then compound 2; then compound 1.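

On the sulfur of the shared core, compound 4 now holds the lowest number in this assay, with three large steps: a 47-fold lower number from compound 3 to compound 4 (1.67 log units; beyond the scatter), a 370-fold lower number from compound 2 to compound 4 (2.57 log units; beyond the scatter) and a 6900-fold lower number from compound 1 to compound 4 (3.84 log units; beyond the scatter). The aryl group at this position therefore spans a wider range than the three earlier thioethers showed, and the lowest number no longer belongs to a chlorine-bearing phenyl. By count, 3-nitrophenyl brings hydrogen-bond acceptors where 3,4-dichlorophenyl has none, but nothing available explains the size of this step.

Compound 4 is the only nitro-bearing thioether shown, so the compounds cannot separate a contribution of the nitro group from that of losing the two chlorines. From the compounds shown here alone, it also remains open whether a nitrile, a carboxylic acid or a methyl ester on the same phenyl would give a number near that of compound 4 or one nearer that of compound 3.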